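This account rests on a few compounds, and the source may have more. Where it says the series, first, only, none or still open, it means among the compounds named here.

Measured so far:
- compound 1 `C[C@@]1(c2ccc3c(N)ncnn23)O[C@H](CO)[C@@H](O)[C@H]1O`: 0.0508 nM
- compound 2 `CC(C)(C)C(=O)SCCOP(=O)(OCCSC(=O)C(C)(C)C)OC[C@H]1O[C@@](C#N)(c2ccc3c(N)ncnn23)[C@H](O)[C@@H]1O`: 4.22 nM

In an in vivo ADME assay on the whole organism (Huh-7 cells, Homo sapiens) for pharmacokinetics, read by LC-MS, with a stated time of 24 h, tested at 10 uM, at a dose of 10 uM (a lower number here means less compound in the circulation, a higher number more compound in the circulation at the dose given), compound 2 gives 4.22 nM, the higher of the two numbers shown, while compound 1 gives 0.0508 nM, a gap well beyond the scatter. Compound 3 `C#C[C@@]1(c2ccc3c(N)ncnn23)O[C@H](COP(=O)(OCCSC(=O)C(C)(C)C)OCCSC(=O)C(C)(C)C)[C@@H](O)[C@H]1O` is not yet measured. It differs from compound 2 only in one place: ethynyl in place of cyano on a saturated ring carbon. Both compounds carry the same large group and the same shared core, so only a small step in this assay is expected, if any, and it is estimated to fall within the scatter, as a 1.2-fold lower number from compound 2 to compound 3 (0.08 log units; within the scatter). Compound 3 is expected to give about 3.5 nM, between 1.2 nM and 10 nM.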

Compound 3, maximal plasma concentration: 0.15 nM
Beside the measured number, compound 3's estimate is 23-fold (1.37 log units) above it; measured number outside the range, below it.
By their numbers in this assay, from the lowest: compound 1; then compound 3; then compound 2.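

In this assay, among these compounds, the change from cyano to ethynyl on this saturated ring carbon gives a 28-fold lower number from compound 2 to compound 3 (1.45 log units; beyond the scatter) and this is the first direct view of the position, showing that the number is sensitive to which of these two small groups it carries. The two groups match in heavy-atom count and each holds a triple bond, so those counts alone do not track the number here. Nothing available accounts for the size of this step. Among the compounds shown here, compound 1 differs from both others in more than one place, so it adds no step at this position. Going by these compounds, how an amine or a longer chain on the same carbon would read remains open.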